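From compound 2 to compound 4: methylcarbamoyl to carboxy

The source may hold more compounds than are shown below. What is called first, only, known or untested is meant among the compounds shown, and "the series" means these compounds.

In an ADME assay on microsomes from liver (Rattus norvegicus) for metabolic stability (a higher number here means that the compound lasts longer, a lower number that the compound disappears faster), compound 1 `COc1cc(OCc2cccc(-c3ccc(OC)nc3)c2)c2cc(-c3cn4nc(OC)sc4n3)oc2c1` gives 0.633 h, compound 2 `CNC(=O)c1ccc(-c2nc(COc3cc(OC)cc4oc(-c5cn6nc(OC)sc6n5)cc34)cs2)cc1` gives 0.517 h and compound 3 `COc1cc(OCc2cccc(-c3cncnc3)c2)c2cc(-c3cn4nc(OC)sc4n3)oc2c1` gives 0.117 h. Compound 2 therefore sits within the scatter of compound 1, while compound 3 has a lower number beyond the scatter.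

Compound 4 `COc1cc(OCc2csc(-c3ccc(C(=O)O)cc3)n2)c2cc(-c3cn4nc(OC)sc4n3)oc2c1` differs from compound 2 by hydroxy in place of methylamino on a carbonyl carbon, which turns 4-(methylcarbamoyl)phenyl into 4-carboxyphenyl: hydroxy in place of methylamino on a carbonyl carbon.

For the measured compounds named here, no measured step covers this exchange. Going by the values given here, the only step available is a 5.4-fold lower number from compound 1 to compound 3 (0.73 log units; beyond the scatter), with pyrimidin-5-yl in place of 6-methoxypyridin-3-yl on an aromatic carbon. That is a different exchange on a different kind of atom, so it bears only indirectly. It shows that one exchange in this small set can move the number in this assay beyond the scatter, but it gives no direction for the present change. The range is kept wide for that reason, and no shift beyond the scatter is predicted.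

The expected change is a 1.2-fold higher number from compound 2 to compound 4 (0.06 log units; within the scatter), an estimate that stays within the scatter. For compound 4 the estimated half-life is 0.6 h, with an expected range of 0.25 h to 1.4 h.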

Compound 4, half-life: > 2 h
Compound 4 gave a limit, no number; the forecaster's own chance of this, stated with the estimate: 5%; at least 3.3-fold (0.52 log units) between middle value and limit.
By their numbers in this assay, from the lowest: compound 3; then compounds 2 and 1 (each within the scatter of the next). At a limit, above all of these: compound 4.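

Hydroxy in place of methylamino on a carbonyl carbon gives an at least 3.8-fold higher number from compound 2 to compound 4 (0.58 log units; beyond the scatter) in this assay, so this place in the series, untouched by the earlier step, can move the half-life beyond the scatter, and the direction here is upward. Compound 4 stands at a limit of the assay and not at a number, so the size of this step is only a lower bound: the limit of > 2 h in this assay, at which 1 of the 4 values shown sits. The earlier step, a 5.4-fold lower number from compound 1 to compound 3 (0.73 log units; beyond the scatter), is a different exchange on an aromatic carbon and runs the other way, so the series now holds one change in each direction, each from a single pair.

The compounds shown do not separate a gain tied to hydroxy itself from one tied to the departure of methylamino, and a primary amide or a methyl ester on the same carbonyl carbon would bear on that question. From the compounds shown here alone, how far the half-life of compound 4 lies past its limit also stays open, as does whether the exchange gives a similar step on any other compound.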